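Swapping the Aryl Group: Expected Inhibition of Compound 4

The compounds below may be only part of what the source reports. "The series", "measured", "known", "first", "only" and "open" are said of these compounds alone.

In a functional assay on NCI-H520 cells (Homo sapiens) for inhibition, read by MTT assay, with a stated time of 48 h, tested at 10 uM (a higher number here means more inhibition at the concentration tested (going by the name of the read-out), a lower number less inhibition), the measured compounds are:
compound 1, `COc1cc(NC(=O)Nc2cc(Nc3ccc(OC)c(C)c3)ncn2)cc(OC)c1`, gives 13.5%;
compound 2, `COc1cc(NC(=O)Nc2cc(Nc3cc(Br)ccc3OC)ncn2)cc(OC)c1`, gives 43.5%;
compound 3, `CCc1cccc(Nc2cc(NC(=O)Nc3cc(OC)cc(OC)c3)ncn2)c1`, gives 23%.

Compound 3 stands second highest of the three numbers: its nearest neighbour is compound 1, within the scatter, and its furthest is compound 2, beyond the scatter. Compound 4, `COc1cc(NC(=O)Nc2cc(Nc3ccc(C)c(F)c3)ncn2)cc(OC)c1`, differs from compound 3 by 3-fluoro-4-methylphenyl in place of 3-ethylphenyl on a nitrogen on an aromatic ring. Two measured steps change the same group on the same nitrogen. The step of a number 9.5 percentage points higher from compound 1 to compound 3 (within the scatter) stayed within the scatter, while a number 20.5 percentage points lower from compound 2 to compound 3 (beyond the scatter) was modest. Only the 5-bromo-2-methoxyphenyl group gave a clearly higher number; the other two groups gave numbers within the scatter of each other. Compound 4 is therefore expected to show a step of about a number 2 percentage points lower from compound 3 to compound 4 (within the scatter), not beyond the scatter. Compound 4 is estimated at 21%, with a range from 8% to 38%.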

Compound 4, a percentage reported as inhibition, at one concentration (the size of the read-out at that concentration, not a potency): 30.6%
The estimate for compound 4 lay 9.6 percentage points below the measured number; measured number inside the range.
By their numbers in this assay, from the lowest: compounds 1, 3 and 4 (each within the scatter of the next, the first and the last beyond it); then compound 2.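

In this assay, the aryl group on this nitrogen no longer shows one high compound against a low pair, but a graded picture: a number 17.1 percentage points higher from compound 1 to compound 4 (beyond the scatter), and a number 12.9 percentage points lower from compound 2 to compound 4 (beyond the scatter). Putting 3-fluoro-4-methylphenyl in place of 3-ethylphenyl, with the same count of heavy atoms, gives a number 7.6 percentage points higher from compound 3 to compound 4 (within the scatter). Nothing available gives a reason for these steps.

Whether the fluorine or the methyl accounts for the value of compound 4 stays open. So does how an amine or a carboxylic acid on this phenyl ring would read.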